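Swapping the aryl substituent on the shared core

The source may report more compounds than this note shows. Statements on the series, on what has been measured and on what is new or still open speak of the compounds shown alone.

Measured so far in an assay on HEK293 cells for inhibition of transient receptor potential cation channel subfamily M member 8 (Homo sapiens), read by FLIPR, with stated times of 5 min and 3 min; a higher number here means a weaker inhibitor, a lower number a stronger inhibitor:
compound 1 `CCn1nnc(-c2sc(-c3cccc(N)c3)nc2O)n1` gives 61 nM
compound 2 `CCn1nnc(-c2sc(-c3cccc(N(C)C)c3)nc2O)n1` gives 4770 nM
compound 3 `O=C(c1sc(-c2cccc(F)c2)nc1O)N1CCCOC1` gives > 100000 nM

Compound 3 is a limit of this assay, not a number. Among the two numbers, compound 2 has the higher one; its nearest neighbour is compound 1, and the single measured step, a 78-fold higher number from compound 1 to compound 2 (1.89 log units; beyond the scatter), is the only comparison that bears on what follows.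

The next compound, compound 4 `CCn1nnc(-c2sc(-c3cccc(OC)c3)nc2O)n1`, is made from compound 2 by one change: methoxy in place of dimethylamino on an aromatic carbon. A methoxy group is smaller than the dimethylamino it replaces, so the change moves back toward the size of the amino group in compound 1. The large step from compound 1 to compound 2 shows that this position is sensitive to what sits there, and a partial return is the likeliest outcome. Compound 4 is therefore expected to give a lower number than compound 2, though not necessarily as low as compound 1: the estimated value is 700 nM, with a range from 120 nM to 4000 nM, meaning an expected step of a 6.8-fold lower number from compound 2 to compound 4 (0.83 log units; beyond the scatter).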

Compound 4, half-maximal inhibitory concentration: 245 nM
Compound 4: middle estimate off by 2.9-fold (0.46 log units), on the high side, and the stated range covers the measured number.
By their numbers in this assay, from the lowest: compound 1; then compound 4; then compound 2. At a limit, above all of these: compound 3.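

Dimethylamino is not simply the upper end of what this position allows: replacing it with methoxy brings a 19-fold lower number from compound 2 to compound 4 (1.29 log units; beyond the scatter). This recovers much of the ground between compound 2 and compound 1. Even so, the position still tells methoxy from amino, as the change between those two groups gives a 4.0-fold higher number from compound 1 to compound 4 (0.60 log units; beyond the scatter) and leaves compound 1 with the lowest number of the three. Dimethylamino and methoxy have the same listed counts of hydrogen-bond donors and acceptors, so those counts cannot account for the large gap between compound 2 and compound 4.

As far as these compounds go, it remains open whether a methylamino group, a hydroxyl or an ethoxy group on this carbon would fall nearer compound 1 or compound 4. Nothing measured here explains why these groups differ in this way.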